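Turning one stereocentre in a side chain

The source may report more compounds than this note shows. Statements on the series, on what has been measured and on what is new or still open speak of the compounds shown alone.

In a functional assay on U-937 cells (Homo sapiens) for antiproliferative activity, read by MTT assay, with a stated time of 24 h (a higher number here means a weaker inhibitor, a lower number a stronger inhibitor), compound 1 `CCCCc1oc2ccccc2c1C(=O)c1ccc(OCC(=O)N2CCCCC2)cc1` gives 37100 nM and compound 2 `CCCCc1oc2ccccc2c1C(=O)c1ccc(OCC(=O)N[C@@H](C)c2ccccc2)cc1` gives 33800 nM. Among the measured compounds shown here, the only measured step, a 1.1-fold lower number from compound 1 to compound 2 (0.04 log units; within the scatter), puts (1-phenylethyl)amino in place of piperidin-1-yl on a carbonyl carbon, so neither compound can be ranked over the other. Compound 3 `CCCCc1oc2ccccc2c1C(=O)c1ccc(OCC(=O)N[C@H](C)c2ccccc2)cc1` changes compound 2 in the subtlest way: the two compounds have the same atoms and bonds and differ only in configuration as drawn: 1 of 1 stereo elements differ; a stereocentre at a saturated chain carbon is drawn S in compound 2 and R in compound 3. That is, a stereocentre at a saturated chain carbon is drawn S in compound 2 and R in compound 3. For the measured compounds named here, no measured pair here tests a change of configuration, so the evidence is indirect. Replacing the whole group made little difference, as a 1.1-fold lower number from compound 1 to compound 2 (0.04 log units; within the scatter) shows, and this gives no reason to predict a shift beyond the scatter in this assay. The expected change is small, a 1.0-fold higher number from compound 2 to compound 3 (0.02 log units; within the scatter). For compound 3 the estimated value is 35000 nM, with an expected range of 20000 nM to 60000 nM.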

Compound 3, half-maximal inhibitory concentration: 19800 nM
Estimate against measurement, compound 3: 1.8-fold (0.25 log units) above; the whole stated range lies above it.
By their numbers in this assay, from the lowest: compounds 3, 2 and 1 (each within the scatter of the next).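

Compounds 2 and 3 give the first direct test of configuration at this saturated chain carbon, and the comparison is clean because nothing else separates them: the fact that compounds 2 and 3 differ only in the configuration as drawn. In this assay the reading is a 1.7-fold lower number from compound 2 to compound 3 (0.23 log units; within the scatter), so the S and R forms cannot be told apart in this assay. Replacing piperidin-1-yl with the R form of (1-phenylethyl)amino gives a 1.9-fold lower number from compound 1 to compound 3 (0.27 log units; within the scatter), so neither this replacement nor the S form in the earlier step moves the number beyond the scatter.

These three compounds leave open whether any group on this carbonyl carbon can move the number clearly, such as a carboxylic acid-bearing chain or a simple amine. A longer chain in place of the 1-phenylethyl group is also untested by the compounds shown here.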